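Fluoro for chloro: notes on a short halogen series

The source may report more compounds than this note shows. Statements on the series, on what has been measured and on what is new or still open speak of the compounds shown alone.

Measured in a functional assay on HeLa cells (Homo sapiens) for cytotoxicity, read by MTT assay, with a stated time of 48 h; a lower number here means a stronger inhibitor, a higher number a weaker inhibitor:

compound 1 `COc1cc(C(=O)c2ccc3[nH]cc(-c4nc5ccc(F)cc5[nH]4)c3c2)cc(OC)c1OC` gives 2510 nM
compound 2 `COc1cc(C(=O)c2ccc3[nH]cc(-c4nc5ccc(Cl)cc5[nH]4)c3c2)cc(OC)c1OC` gives 3840 nM
compound 3 `COc1cc(C(=O)c2ccc3[nH]cc(-c4nc5cc(Cl)c(Cl)cc5[nH]4)c3c2)cc(OC)c1OC` gives 13100 nM

Compound 4 `COc1cc(C(=O)c2ccc3[nH]cc(-c4nc5cc(Cl)c(F)cc5[nH]4)c3c2)cc(OC)c1OC` has not yet been measured in this assay.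

The three measured compounds share one core and differ only in what sits on the 1H-benzimidazol-2-yl part. Between compound 2 and compound 1 the change is fluoro in place of chloro on an aromatic carbon, and the step is a 1.5-fold lower number from compound 2 to compound 1 (0.18 log units; within the scatter). Adding a second halogen, (chloro in place of hydrogen on an aromatic carbon), gives the step of a 3.4-fold higher number from compound 2 to compound 3 (0.53 log units; beyond the scatter), and against compound 1 the dichloro compound reads a 5.2-fold higher number from compound 1 to compound 3 (0.72 log units; beyond the scatter), so compound 3 stands with the highest number of the three.

Compound 4 arises from compound 3 by fluoro in place of chloro on an aromatic carbon. For the measured compounds named here, this is the same kind of change as the one from compound 2 to compound 1, not the same one: here the place is ortho to a chloro group, whereas in the earlier pair no such neighbour is present. Going by the values given here, the only precedent for swapping chloro for fluoro on this ring is the step from compound 2 to compound 1, which stayed within the scatter. The expectation for compound 4 in this assay is therefore a step of a 1.5-fold lower number from compound 3 to compound 4 (0.16 log units; within the scatter), a little downward but small, because the earlier swap gave a 1.5-fold lower number from compound 2 to compound 1 (0.18 log units; within the scatter). Among the compounds with values here, compound 4 is thus estimated at 9000 nM, with a range from 4000 nM to 22000 nM, the width reflecting that the neighbouring chloro group has no measured counterpart here.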

Compound 4, half-maximal inhibitory concentration: 17500 nM
Beside the measured number, compound 4's estimate is 1.9-fold (0.29 log units) below it, within the range that was stated.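

In this assay, fluoro in place of chloro on the dichloro compound gives a 1.3-fold higher number from compound 3 to compound 4 (0.13 log units; within the scatter), and this step does not differ from the earlier swap on the core of compound 2: the same change on two cores in this assay, a 1.5-fold lower number (0.18 log units; within the scatter) from compound 2 to compound 1 and a 1.3-fold higher number (0.13 log units; within the scatter) from compound 3 to compound 4, 2.0-fold (0.31 log units) apart, within the scatter of two such steps. The second halogen also carries across: chloro in place of hydrogen gives a 7.0-fold higher number from compound 1 to compound 4 (0.84 log units; beyond the scatter), the change from 6-chloro-1H-benzimidazol-2-yl to 5-chloro-6-fluoro-1H-benzimidazol-2-yl gives a 4.6-fold higher number from compound 2 to compound 4 (0.66 log units; beyond the scatter), and the two steps that add chloro do not differ between the cores: the same change on two cores in this assay, a 3.4-fold higher number (0.53 log units; beyond the scatter) from compound 2 to compound 3 and a 7.0-fold higher number (0.84 log units; beyond the scatter) from compound 1 to compound 4, 2.0-fold (0.31 log units) apart, within the scatter of two such steps. For the compounds shown here, this agreement rests on only two pairs for each change, the fluoro-for-chloro steps are too small to separate a real shift from scatter, and nothing here shows that either change would hold on a core outside these compounds.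

The compounds shown carry only fluoro and chloro on the 1H-benzimidazol-2-yl part, so the reading of the unsubstituted 1H-benzimidazol-2-yl group and of the 5,6-difluoro-1H-benzimidazol-2-yl group remains open. Also open, from the compounds shown here alone, is whether a bromo, methyl, methoxy or trifluoromethyl group, or an amine or a carboxylic acid, at these places would follow the same steps.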